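A few compounds are considered here, and "the series" means these few. Any claim that something is new, unique, unknown or untested is made for them only; others in the source may bear on it.

Measured so far:
Compound 1, `Oc1nc2nonc2nc1Nc1ccc(OC(F)(F)F)cc1Cl`, in an assay on mitochondria from L6 cells (Rattus norvegicus) for activation, with a stated time of 90 min (a higher number here means that more compound is needed for the effect, a lower number that less compound is needed), gives 1400 nM.
Compound 2, `CCCCOc1ccc(Nc2nc3nonc3nc2O)cc1`, in this assay gives 3700 nM.

Of these two numbers, compound 2 stands at the higher one, and its value in this assay lies beyond the scatter from that of compound 1. Compound 3, `Oc1nc2nonc2nc1Nc1ccc(C(F)(F)F)cc1`, has not yet been measured. It differs from compound 2 in one place: trifluoromethyl in place of butoxy on an aromatic carbon. Going by the values given here, no step between measured compounds matches this change, so the expected direction rests on the two numbers alone. Compound 3 is expected to need less compound than compound 2, by an estimated step of a 1.9-fold lower number from compound 2 to compound 3 (0.27 log units; within the scatter). For compound 3 the estimate in this assay is 2000 nM, within a range of 600 nM to 7000 nM.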

Compound 3, half-maximal effective concentration: 10400 nM
Compound 3: middle estimate off by 5.2-fold (0.72 log units), on the low side; measured number above the stated range.
By their numbers in this assay, from the lowest: compound 1; then compound 2; then compound 3.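

In this assay, trifluoromethyl in place of butoxy on this aromatic carbon gives a 2.8-fold higher number from compound 2 to compound 3 (0.45 log units; beyond the scatter). Going by these compounds alone, this is the first one-place comparison, and it shows that the group at this position changes the number beyond the scatter, with butoxy the better of the two. No measurement shown accounts for this step.

As far as these compounds go, whether the chain or its oxygen matters remains open. A plain butyl chain, a methoxy group or a longer alkoxy chain on this carbon would separate the two.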